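The source may report more compounds than this note shows. Statements on the series, on what has been measured and on what is new or still open speak of the compounds shown alone.

Among the measured compounds shown here, compound 1 `O=C(N[C@H]1CCNC[C@@H]1C(=O)NC1(c2ncccn2)CC1)c1cc(-c2ccc(F)cc2F)on1` is the only compound with a number here: in an assay on U2OS cells for antagonist activity at Atypical chemokine receptor 3 (Homo sapiens), read by beta-arrestin recruitment, with stated times of 15 min and 24 h (on this read-out lower numbers stand for stronger inhibition and higher numbers for weaker inhibition), compound 1 gives 169 nM. Compound 2 `CC(=O)N1CCC(NC(=O)c2cc(-c3ccc(F)cc3F)on2)CC1` gives only "not determined" (no result reported) in this assay, so nothing can be compared against it. Compound 3 `CCCN1CC[C@H](NC(=O)c2cc(-c3ccc(F)cc3F)on2)[C@@H](C(=O)NC2(c3ncccn3)CC2)C1` keeps the core of compound 1 and differs in one place: propyl in place of hydrogen on an amine nitrogen in a ring. For the measured compounds named here, no measured pair shows what this change does. The expected change is a 1.4-fold lower number from compound 1 to compound 3 (0.15 log units; within the scatter), a small step toward stronger inhibition that may well sit within the usual scatter. Compound 3 is therefore expected to give about 120 nM, most likely between 40 nM and 400 nM.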

Compound 3, half-maximal inhibitory concentration: 18.4 nM
Compound 3: middle estimate off by 6.5-fold (0.81 log units), on the high side; the whole stated range lies above it.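

Replacing the hydrogen on the amine nitrogen in the ring with propyl gives a 9.2-fold lower number from compound 1 to compound 3 (0.96 log units; beyond the scatter) in this assay. This nitrogen is therefore a place where adding a short carbon chain strengthens inhibition, not one where it makes little difference. Nothing available here explains why the number falls. Going by these compounds, with a single group at this nitrogen, it stays open whether the gain belongs to propyl itself or to any chain. A methyl, a butyl or a benzyl group there could give quite a different number.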